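Aryl ketone replacement in a growth-inhibition series

A few compounds are considered here, and "the series" means these few. Any claim that something is new, unique, unknown or untested is made for them only; others in the source may bear on it.

Measured so far:
compound 1 `COc1cc(-c2cc(/C=C/C(=O)c3ccc(N)cc3)[nH]n2)cc(OC)c1OC` — 7020 nM
compound 2 `COc1ccc(-c2cc(/C=C/C(=O)c3ccc(N)cc3)[nH]n2)cc1OC` — 10100 nM

In a functional assay on A549 cells (Homo sapiens) for inhibition, read by sulforhodamine B assay, with a stated time of 48 h (on this read-out lower numbers stand for stronger inhibition of growth and higher numbers for weaker inhibition of growth), compound 1 gives the lowest of the two numbers; its nearest neighbour is compound 2, with a 1.4-fold higher number from compound 1 to compound 2 (0.16 log units; within the scatter), so the two are indistinguishable here. Compound 3 `COc1cc(-c2cc(/C=C/C(=O)c3ccc(F)c(F)c3)[nH]n2)cc(OC)c1OC` differs from compound 1 by 3,4-difluorophenyl in place of 4-aminophenyl on a carbonyl carbon. Among the compounds with values here, the only measured step concerns a methoxy on the other aromatic ring and does not bear on this change, so no direction can be drawn from the data. Compound 3 is therefore expected near compound 1, at 7000 nM within 2500 nM to 20000 nM, an expected step of a 1.0-fold lower number from compound 1 to compound 3 (0.00 log units; within the scatter).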

Compound 3, concentration for total growth inhibition: 9900 nM
Estimate against measurement, compound 3: 1.4-fold (0.15 log units) below; low and high end bracket the measured number.
By their numbers in this assay, from the lowest: compounds 1, 3 and 2 (each within the scatter of the next).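

In this assay, 3,4-difluorophenyl in place of 4-aminophenyl on the carbonyl carbon gives a 1.4-fold higher number from compound 1 to compound 3 (0.15 log units; within the scatter). Within the data shown here, this is the first reading at this position: a group with 0 hydrogen-bond donors and 0 hydrogen-bond acceptors is not told apart from 4-aminophenyl, which has 1 of each. No measured evidence accounts for this result.

Still open, on these data alone, is whether any group on the carbonyl carbon moves the number beyond the scatter. A nitrile-bearing phenyl or a saturated alkyl chain in that place, read against compound 1, would test this.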